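Three methoxy groups replace the ethoxy in compound 4

This account rests on a few compounds, and the source may have more. Where it says the series, first, only, none or still open, it means among the compounds named here.

Among the measured compounds, compound 3 `CCCCCCCCCCCCCCCCCCNC(=O)[C@@H]1CSC(c2ccc(OCC)cc2)N1` stands highest: in a functional assay on LNCaP cells (Homo sapiens) for antiproliferative activity, read by sulforhodamine B assay (a lower number here means a stronger inhibitor, a higher number a weaker inhibitor), compound 3 gives 6100 nM, while compound 1 `CCCCCCCCCCCCCCCCCCNC(=O)[C@@H]1CSC(c2ccc(OC)cc2)N1` gives 2100 nM and compound 2 `CCCCCCCCCCCCCCCCCCNC(=O)[C@@H]1CSC(c2ccc(N(C)C)cc2)N1` gives 1600 nM. The shift a 2.9-fold higher number from compound 1 to compound 3 (0.46 log units; beyond the scatter) was modest, as was a 3.8-fold higher number from compound 2 to compound 3 (0.58 log units; beyond the scatter); by contrast a 1.3-fold lower number from compound 1 to compound 2 (0.12 log units; within the scatter). Compound 4 `CCCCCCCCCCCCCCCCCCNC(=O)[C@@H]1CSC(c2c(OC)cc(OC)cc2OC)N1` carries 2,4,6-trimethoxyphenyl in place of 4-ethoxyphenyl on a saturated ring carbon. Within the data shown here, the methoxy group of compound 1 returns here, repeated across the ring, so the step that bears most on it is the one from compound 1 to compound 3 read in reverse; no measured step covers the additional methoxy groups. The step of a 2.4-fold lower number from compound 3 to compound 4 (0.39 log units; beyond the scatter) is therefore expected to run downward, back toward the number of compound 1. Compound 4 is estimated at 2500 nM, within 800 nM to 8000 nM.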

Compound 4, half-maximal inhibitory concentration: 2400 nM
The estimate for compound 4 lay 1.0-fold (0.02 log units) above the measured number; the range from low to high includes it.
By their numbers in this assay, from the lowest: compounds 2, 1 and 4 (each within the scatter of the next); then compound 3.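

In this assay, the saturated ring carbon carries 2,4,6-trimethoxyphenyl at the same level as 4-methoxyphenyl and 4-(dimethylamino)phenyl, with a 1.1-fold higher number from compound 1 to compound 4 (0.06 log units; within the scatter) and a 1.5-fold higher number from compound 2 to compound 4 (0.18 log units; within the scatter). Only 4-ethoxyphenyl stands apart from the new group, with a 2.5-fold lower number from compound 3 to compound 4 (0.41 log units; beyond the scatter), so a heavier methoxy pattern on this aromatic ring costs nothing measurable here. No evidence bears on why the numbers fall this way. The compounds shown leave open how a hydroxyl or a chlorine on this ring would read, and whether a shorter chain on the amide would keep this level.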